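From a Chlorophenyl Amide to a Quinoline Amide

The source may report more compounds than this note shows. Statements on the series, on what has been measured and on what is new or still open speak of the compounds shown alone.

Measured so far:
compound 1, `CCc1ccc(C(=O)Nc2ccc3nc(N4CCN(CC)CC4)cc(C)c3c2)cc1`, gives 3060 nM
compound 2, `CCN1CCN(c2cc(C)c3cc(NC(=O)c4ccc(Cl)cc4)ccc3n2)CC1`, gives 1530 nM

Both numbers come from a functional assay on MCF7 cells (Homo sapiens) for antiproliferative activity, read by MTT assay, with a stated time of 72 h; on this read-out higher numbers stand for weaker inhibition and lower numbers for stronger inhibition. Among the measured compounds shown here, the only measured step, a 2.0-fold lower number from compound 1 to compound 2 (0.30 log units; within the scatter), lies within the scatter, so compound 2 cannot be told apart from compound 1 and stands at the same level. The unmeasured compound 3, `CCN1CCN(c2cc(C)c3cc(NC(=O)c4ccc5ccccc5n4)ccc3n2)CC1`, differs from compound 2 by quinolin-2-yl in place of 4-chlorophenyl on a carbonyl carbon. That measured step changed a group on an aromatic ring, not the ring itself, so it gives no guide to this exchange, and no step beyond the scatter is expected. Compound 3 is therefore estimated at 1500 nM, within 400 nM to 6000 nM, a step of a 1.0-fold lower number from compound 2 to compound 3 (0.01 log units; within the scatter).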

Compound 3, half-maximal inhibitory concentration: 7060 nM
Compound 3: the middle estimate sits 4.7-fold (0.67 log units) below what was measured; the measured number lies above the stated range.
By their numbers in this assay, from the lowest: compounds 2 and 1 (each within the scatter of the next); then compound 3.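

Replacing the substituted phenyl on the amide carbonyl does move the number in this assay: there is a 4.6-fold higher number from compound 2 to compound 3 (0.66 log units; beyond the scatter), and a 2.3-fold higher number from compound 1 to compound 3 (0.36 log units; beyond the scatter), both modest. The earlier change of a group on the phenyl ring gave no step beyond the scatter, whereas this exchange of the whole ring for quinolin-2-yl does. Nothing measured here accounts for the rise.

Quinolin-2-yl brings both a second ring and a ring nitrogen, and the compounds shown do not separate the two. Going by these compounds, whether pyridin-2-yl or naphthalen-2-yl on that carbonyl would sit nearer compound 2 or compound 3 stays open.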